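From pyridazin-3-yl to phenyl on an aromatic nitrogen

The compounds below may be only part of what the source reports. "The series", "measured", "known", "first", "only" and "open" are said of these compounds alone.

Compound 1 `Cc1ccncc1-c1cccc2c1cnn2-c1nccs1`: 8%
Compound 2 `Cc1ccncc1-c1cccc2c1cnn2-c1cccnn1`: 17%

Among the compounds with values here, in an ADME assay on liver (Mus musculus) for metabolic stability, using microsomes, with a stated time of 10 min, tested at 0.5 uM (on this read-out higher numbers stand for a more stable compound and lower numbers for a less stable compound), compound 2 gives 17%, which lies within the scatter of compound 1, the only other compound measured. The next compound is compound 3 `Cc1ccncc1-c1cccc2c1cnn2-c1ccccc1`, with phenyl in place of pyridazin-3-yl on an aromatic nitrogen. Within the data shown here, one measured step bears on this change, since it falls on the same aromatic nitrogen: a number 9 percentage points higher from compound 1 to compound 2 (within the scatter). Among the measured compounds shown here, that step is small, but no measured compound carries phenyl, so it gives no firm direction for the new group. No step beyond the scatter is therefore expected in this assay. The expected change is a number 5 percentage points lower from compound 2 to compound 3 (within the scatter), which would stay within the scatter. For compound 3 the estimated value is 12%, with an expected range from 4% to 25%.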

Compound 3, percent of the compound remaining: 4%
Compound 3: middle estimate off by 8 percentage points, on the high side; low and high end bracket the measured number.
By their numbers in this assay, from the lowest: compounds 3, 1 and 2 (each within the scatter of the next, the first and the last beyond it).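

In this assay the group on the aromatic nitrogen now gives its first step beyond the scatter, with a number 13 percentage points lower from compound 2 to compound 3 (beyond the scatter) when phenyl, a six-membered aromatic ring of carbon only, takes the place of pyridazin-3-yl, a six-membered aromatic ring with 2 hetero atoms. Phenyl in place of 1,3-thiazol-2-yl gives a number 4 percentage points lower from compound 1 to compound 3 (within the scatter) and so does not separate those two groups, which leaves compound 1 within the scatter of both compound 2 and compound 3. Nothing at hand accounts for the step from pyridazin-3-yl to phenyl.

Going by these compounds, whether a pyridin-2-yl ring on this nitrogen would read closer to compound 2 or to compound 3 remains open. So does the effect of a saturated group there, such as a piperidine or a short alkyl chain.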